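Fluoro for dimethylamino at the assay's limit

The source may report more compounds than this note shows. Statements on the series, on what has been measured and on what is new or still open speak of the compounds shown alone.

Measured in an ADME assay on CEMx174 cells (Homo sapiens) for cytotoxicity; on this read-out lower numbers stand for higher toxicity in this test and higher numbers for lower toxicity in this test:
Compound 1 `CCC1=C(C(=O)OCC2CCCCC2)C(c2ccc(N)cc2)NC(=O)N1` gives > 10000 nM as a limit
Compound 2 `CCC1=C(C(=O)OCC2CCCCC2)C(c2ccc(NC)cc2)NC(=O)N1` gives > 10000 nM as a limit
Compound 3 `CCC1=C(C(=O)OCC2CCCCC2)C(c2ccc(N(C)C)cc2)NC(=O)N1` gives > 10000 nM as a limit

Compound 3 stands at > 10000 nM, which is a limit of the assay and not a number. It has no lower or higher place among the three compounds, which all share the limit of > 10000 nM in this assay, at which 3 of the 3 values shown sit, in this read-out.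

Compound 4 `CCC1=C(C(=O)OCC2CCCCC2)C(c2ccc(F)cc2)NC(=O)N1` carries fluoro in place of dimethylamino on an aromatic carbon, para to a large group, a change counted as fluoro in place of dimethylamino on an aromatic carbon in full.

Within the data shown here, three measured steps concern this substituent: a step that the two limits leave unreadable from compound 1 to compound 2, a step that the two limits leave unreadable from compound 1 to compound 3 and a step that the two limits leave unreadable from compound 2 to compound 3, and none has a readable size. They offer no size or direction to carry over, and none involves fluoro.

No step beyond the scatter is therefore expected in this assay, and the expected step is a step that the limit leaves unreadable from compound 3 to compound 4 in estimate only. For compound 4 the estimated value is 15000 nM, with an expected range from 5000 nM to 40000 nM and a limit the likeliest report.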

Compound 4, half-maximal cytotoxic concentration: > 10000 nM
Compound 4: only a limit was reported (the forecaster's own chance of this, stated with the estimate: 85%); the middle value does not contradict the limit.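

In this assay compound 4 gives > 10000 nM as a limit of the assay and not a number, so its steps from compound 1, compound 2 and compound 3 cannot be read. The compounds shown leave open whether these four differ in cytotoxicity at all, since all rest on one limit: the limit of > 10000 nM in this assay, at which 4 of the 4 values shown sit.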